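The source may report more compounds than this note shows. Statements on the series, on what has been measured and on what is new or still open speak of the compounds shown alone.

Compound 1, `NC(=O)c1cc2ccc(OCC(F)(F)F)cc2n1-c1cccc(CCC(=O)O)c1`: 740 nM
Compound 2, `NC(=O)c1cc2ccc(OC(F)F)cc2n1-c1cccc(CCC(=O)O)c1`: 370 nM

Among the measured compounds shown here, in an assay for inhibition of Group 10 secretory phospholipase A2 (Homo sapiens), with stated times of 20 min and 60 min (on this read-out higher numbers stand for weaker inhibition and lower numbers for stronger inhibition), compound 2 gives 370 nM and compound 1 gives 740 nM; the single measured step, a 2.0-fold lower number from compound 1 to compound 2 (0.30 log units; within the scatter), lies within the scatter, so the two stand level. Compound 3, `NC(=O)c1cc2ccc(C3CC3)cc2n1-c1cccc(CCC(=O)O)c1`, differs from compound 2 by cyclopropyl in place of difluoromethoxy on an aromatic carbon. That one step bears on it only loosely, since the oxygen itself was kept there; nothing measured removes it. No movement beyond the scatter in this assay is therefore expected. For compound 3 the estimate is 450 nM, between 150 nM and 1500 nM, which is expected to mean a 1.2-fold higher number from compound 2 to compound 3 (0.09 log units; within the scatter).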

Compound 3, half-maximal inhibitory concentration: 1900 nM
Compound 3: middle estimate off by 4.2-fold (0.63 log units), on the low side, outside the stated range (above it).
By their numbers in this assay, from the lowest: compounds 2 and 1 (each within the scatter of the next); then compound 3.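

In this assay the aromatic carbon carrying these groups proves sensitive to the change, with a 5.1-fold higher number from compound 2 to compound 3 (0.71 log units; beyond the scatter) and a 2.6-fold higher number from compound 1 to compound 3 (0.41 log units; beyond the scatter) both beyond the scatter. Difluoromethoxy and 2,2,2-trifluoroethoxy stand level, whereas cyclopropyl, which carries no oxygen and no fluorine, gives the weakest inhibition of the three. Nothing available explains this loss. From the compounds shown here alone, whether a methoxy group or an ethyl chain would stand with compound 2 or with compound 3 stays open. The loss therefore cannot yet be assigned to the oxygen, the fluorine or the three-membered ring.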